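Methoxy for chloro on the pendant phenyl ring

The source may report more compounds than this note shows. Statements on the series, on what has been measured and on what is new or still open speak of the compounds shown alone.

The series shares one core and varies only the substituent on the phenyl ring attached to the saturated ring carbon. Compound 1 `C=CCc1c(O)cc(O)c2c1OC(c1cccc(Br)c1)CC2=O` carries a 3-bromophenyl group and gives 78.8% in a functional assay on aorta (Rattus norvegicus, strain Sprague-Dawley) for inhibition, with a stated time of 20 min; on this read-out lower numbers stand for smaller maximal responses and higher numbers for larger maximal responses. Compound 2 `C=CCc1c(O)cc(O)c2c1OC(c1cccc(Cl)c1)CC2=O` carries a 3-chlorophenyl group and gives 76.7% in this assay. Compound 3 `C=CCc1c(O)cc(O)c2c1OC(c1ccc(Cl)cc1)CC2=O` carries a 4-chlorophenyl group and gives 77.6% in this assay. Compound 3 thus stands second highest of the three numbers, with compound 2 nearest and compound 1 furthest, but every step among them lies within the scatter: a number 2.1 percentage points lower from compound 1 to compound 2 (within the scatter), a number 1.2 percentage points lower from compound 1 to compound 3 (within the scatter) and a number 0.9 percentage points higher from compound 2 to compound 3 (within the scatter).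

Compound 4 `C=CCc1c(O)cc(O)c2c1OC(c1ccc(OC)cc1)CC2=O` continues this variation of the phenyl substituent: methoxy in place of chloro on an aromatic carbon. The three measured steps all bear on it, since each changes only the halogen or its position on the same ring, and none moved the maximal response beyond the scatter. Going by the values given here, no measured step exchanges a halogen for methoxy, so the direction of any effect is unknown. Compound 4 is therefore expected to show essentially no step beyond the scatter, a number 1.6 percentage points lower from compound 3 to compound 4 (within the scatter), with an estimated maximal response of 76% in this assay, within a range of 64% to 88%.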

Compound 4, largest response reached (Emax), in percent of the reference or control that the assay uses: 81%
Beside the measured number, compound 4's estimate is 5 percentage points below it; measured number inside the range.
By their numbers in this assay, from the lowest: compounds 2, 3, 1 and 4 (each within the scatter of the next).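

Methoxy is the first group in the series at this position that is not a halogen. With 4-methoxyphenyl in place of 4-chlorophenyl, a change that adds a hydrogen-bond acceptor on an aromatic carbon para to a large group, this assay gives a number 3.4 percentage points higher from compound 3 to compound 4 (within the scatter) and so does not separate the two groups. The comparisons with the other halogen-bearing compounds read the same way, with a number 4.3 percentage points higher from compound 2 to compound 4 (within the scatter) against the 3-chlorophenyl group and a number 2.2 percentage points higher from compound 1 to compound 4 (within the scatter) against the 3-bromophenyl group, so the earlier finding that halogen identity and placement leave the maximal response within the scatter now extends to one non-halogen group among these four compounds. Nothing available bears on why the maximal response stays so flat across these groups.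

From the compounds shown here alone, it remains open whether any group at this position can move the maximal response beyond the scatter, and an amine, a carboxylic acid or a longer chain such as butoxy would put that to the test. The compounds also leave open whether the exchange of chloro for methoxy would stay within the scatter on a core carrying other groups.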